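Swapping an amine chain for benzyl on a shared core

This account rests on a few compounds, and the source may have more. Where it says the series, first, only, none or still open, it means among the compounds named here.

Measured compounds:
- compound 1, `CCCCc1sc(-c2ccc(Oc3ccc(Cl)cc3)cc2)nc1-c1ccc(OCCCN(CC)CC)cc1`, 57%
- compound 2, `CCCCc1sc(-c2ccc(OCCCN3CCCC3)cc2)nc1-c1ccc(Oc2ccc(Cl)cc2)cc1`, 47.8%
- compound 3, `CCCCc1nc(-c2ccc(OCCCN(CC)CC)cc2)sc1-c1ccc(Oc2ccc(Cl)cc2)cc1`, 49.6%

All three share a core and were tested in an assay on isolated protein for antagonist activity at advanced glycosylation end product-specific receptor (Homo sapiens), read by ELISA, with a stated time of 60 min, tested at 10 uM; a lower number here means less inhibition, a higher number more inhibition at the concentration tested (going by the name of the read-out). Compound 1 gives 57%, the highest of the three numbers, but both other numbers sit within the usual scatter of it, so nothing separates these compounds beyond measurement noise.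

Compound 4, `CCCCc1sc(-c2ccc(Oc3ccc(Cl)cc3)cc2)nc1-c1ccc(OCc2ccccc2)cc1`, has not yet been measured. It differs from compound 1 in one place: phenyl in place of 2-(diethylamino)ethyl on a saturated chain carbon bound to an oxygen on an aromatic ring. Going by the values given here, no pair of measured compounds shows a change of this kind, so no measured step guides the expectation directly. Since the three measured numbers all lie close together, there is no sign in the data that this part of the molecule has moved the read-out so far. Still, the change removes the chain with its nitrogen entirely and puts a flat ring in its place, which is a larger alteration than any seen here. A modest downward step in this assay is expected, possibly just beyond the scatter, as in the expected step of a number 19 percentage points lower from compound 1 to compound 4 (beyond the scatter). Compound 4 is therefore estimated at 38%, within a range from 18% to 58%.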

Compound 4, a percentage reported as inhibition, at one concentration (the size of the read-out at that concentration, not a potency): 2.4%
Compound 4: middle estimate off by 35.6 percentage points, on the high side; the whole stated range lies above it.
By their numbers in this assay, from the lowest: compound 4; then compounds 2, 3 and 1 (each within the scatter of the next).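

In this assay, exchanging 3-(diethylamino)propoxy for benzyloxy gives a number 54.6 percentage points lower from compound 1 to compound 4 (beyond the scatter) and shows that this position is far from indifferent to what it carries. The earlier compounds shown here all keep an amine chain, so their close numbers could not reveal this; compound 4 has no nitrogen in that chain and reads 2.4% in the same test. No accompanying measurement bears on why the read-out falls.

This single change removes the amine and adds a phenyl ring together, so the compounds shown do not say which of the two matters. A plain butoxy chain without nitrogen, or a benzyloxy group carrying a dimethylaminomethyl group on its ring, would separate the two.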